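Swapping a cyclopropyl for a hydroxyethyl on the shared core

This account rests on a few compounds, and the source may have more. Where it says the series, first, only, none or still open, it means among the compounds named here.

Compound 1 `CC(C)c1nccc2nn(-c3ccccc3)cc12`: > 100000 nM
Compound 2 `Cc1nc(C2CC2)cc2nn(-c3ccccc3)cc12`: 25900 nM
Compound 3 `CCCCCc1cc2nn(-c3ccccc3)cc2cn1`: 2100 nM

Three compounds on a shared core were tested in a functional assay on K562 cells (Homo sapiens) for inhibition, read by fluorescence, with a stated time of 72 h; a lower number here means a stronger inhibitor of growth, a higher number a weaker inhibitor of growth. For compound 1 the result is a limit of the assay, not a number: > 100000 nM, that is the limit of > 100000 nM in this assay, at which 1 of the 3 values shown sits. Among the two real numbers, compound 2 gives 25900 nM, the higher of the two, while compound 3 gives 2100 nM, a gap beyond the usual scatter.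

Compound 4 `Cc1nc(CCO)cc2nn(-c3ccccc3)cc12` has not yet been measured in this assay. It differs from compound 2 by one change: 2-hydroxyethyl in place of cyclopropyl on an aromatic carbon. Among the measured compounds shown here, no measured pair shows this kind of change, so the expectation rests on the spread of the three values alone. A weakening of roughly a 1.7-fold higher number from compound 2 to compound 4 (0.24 log units; within the scatter) is expected, though a result within the scatter would not surprise. Compound 4 is estimated at 45000 nM, with a range from 8000 nM to 200000 nM.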

Compound 4, concentration for 50% growth inhibition: > 100000 nM
Compound 4: no number, only a limit; the forecaster's own chance of this, stated with the estimate: 30%; at least 2.2-fold (0.34 log units) between middle value and limit.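

In this assay, the only one-place comparison shown puts 2-hydroxyethyl in place of cyclopropyl on the aromatic carbon next to the ring nitrogen, and the result is an at least 3.8-fold higher number from compound 2 to compound 4 (0.58 log units; beyond the scatter). The two groups have the same count of heavy atoms, so this position responds to the kind of group and not only to its size. The result for compound 4 is a limit, not a number, so the true size of the step stays unknown: the limit of > 100000 nM in this assay, at which 2 of the 4 values shown sit.

On these data alone, whether the hydroxyl or the lost ring matters more remains open. A plain ethyl or a methoxyethyl group at this position could separate the two.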